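Swapping isopropoxy for chloro at the assay limit

The source may report more compounds than this note shows. Statements on the series, on what has been measured and on what is new or still open speak of the compounds shown alone.

Measured in an ADME assay on ECV-304 cells (Homo sapiens) for cytotoxicity, read by MTT assay, with a stated time of 72 h; a lower number here means a stronger inhibitor, a higher number a weaker inhibitor:
Compound 1 `COc1ccc(C2=C(c3cc(OC)c(OC)c(OC)c3)C(=O)C(OC(C)=O)C2)cc1OC(C)C`: > 100 ug/mL, a limit
Compound 2 `COc1ccc(C2=C(c3cc(OC)c(OC)c(OC)c3)C(=O)C(O[SiH2]C(C)(C)C)C2)cc1OC(C)C`: > 100 ug/mL, a limit

Compound 1 gives no number in this assay, only the limit > 100 ug/mL. The whole record so far is the limit of > 100 ug/mL in this assay, at which 2 of the 2 values shown sit.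

Compound 3 `COc1ccc(C2=C(c3cc(OC)c(OC)c(OC)c3)C(=O)C(OC(C)=O)C2)cc1Cl` shares its core with compound 1 and departs from it at one place: chloro in place of isopropoxy on an aromatic carbon. This is chloro in place of isopropoxy on an aromatic carbon, ortho to a methoxy group.

Going by the values given here, only one measured step exists, a step that the two limits leave unreadable from compound 1 to compound 2. It concerns an oxygen on a saturated carbon, not the aromatic carbon changed here, and its size cannot be read. It therefore offers no measure for the new change, and no particular shift in either direction is expected in this assay. A reading at or near the limit of compound 1 is thought more likely than a clear gain.

The expected step is a number no higher from compound 1 to compound 3 (the limit leaves the size open). For compound 3 the estimated value is 100 ug/mL, with an expected range of 30 ug/mL to 300 ug/mL.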

Compound 3, half-maximal inhibitory concentration: 3.5 ug/mL
Compound 3: the middle estimate sits 29-fold (1.46 log units) above what was measured; the measured number lies below the stated range.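

In this assay, chloro in place of isopropoxy on an aromatic carbon gives an at least 28-fold lower number from compound 1 to compound 3 (1.45 log units; beyond the scatter), which makes compound 3 the only one of the compounds shown to return a number rather than a limit. Going by these compounds alone, the earlier step, at an oxygen on a saturated carbon, cannot be read, so this aromatic carbon, ortho to a methoxy group, is the one place where a change in structure registers as a readable shift, and the measured record is otherwise confined to a single boundary: the limit of > 100 ug/mL in this assay, at which 2 of the 3 values shown sit. The result therefore shows that the shared core is not inactive by itself in this assay, and that the group at this one position can carry it from the limit to a measurable value.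

The single pair cannot separate the loss of isopropoxy from the arrival of chloro, and the compounds shown leave open whether a hydroxyl, a bromo or a plain hydrogen at this carbon would give a similar reading. They also leave open whether, with chloro in place, exchanging the acetate on the saturated carbon would now produce a step that can be read.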